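Para-substituent swap on a phthalimide-derived aniline series

The source may hold more compounds than are shown below. What is called first, only, known or untested is meant among the compounds shown, and "the series" means these compounds.

Compound 1 `O=C1c2ccccc2C(=O)N1CNc1ccc(F)cc1`: 56.7%
Compound 2 `CCc1ccc(NCN2C(=O)c3ccccc3C2=O)cc1`: 63%
Compound 3 `O=C1c2ccccc2C(=O)N1CNc1ccc(O)cc1`: 101%

In an assay on isolated protein for inhibition of ribosomal protein S6 kinase alpha-2 (Homo sapiens), read by fluorescence, with a stated time of 20 min, tested at 10 uM (a higher number here means more inhibition at the concentration tested (going by the name of the read-out), a lower number less inhibition), compound 1 gives the lowest of the three numbers; compound 2 sits nearest, with a number 6.3 percentage points higher from compound 1 to compound 2 (within the scatter), while compound 3 lies furthest, with a number 44.3 percentage points higher from compound 1 to compound 3 (beyond the scatter). Compound 4 `CCOc1ccc(NCN2C(=O)c3ccccc3C2=O)cc1` differs from compound 1 by ethoxy in place of fluoro on an aromatic carbon. Both measured steps from compound 1 bear on this: the ethyl step stayed within the scatter, the hydroxy step was large. Ethoxy shares the oxygen link of hydroxy but carries no donor, so a moderate rise is expected, roughly a number 13.3 percentage points higher from compound 1 to compound 4 (beyond the scatter). Compound 4 is therefore estimated at 70%, in the range 50% to 95%.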

Compound 4, a percentage reported as inhibition, at one concentration (the size of the read-out at that concentration, not a potency): 100%
Compound 4: middle estimate off by 30 percentage points, on the low side; the whole stated range lies below it.
By their numbers in this assay, from the lowest: compounds 1 and 2 (each within the scatter of the next); then compounds 4 and 3 (each within the scatter of the next).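

In this assay the step is a number 1 percentage points lower from compound 3 to compound 4 (within the scatter) with ethyl in place of the hydrogen on the oxygen, so that hydrogen is not required for the high number at this position. The oxygen link goes with the high numbers: there is a number 37 percentage points higher from compound 2 to compound 4 (beyond the scatter) with ethoxy in place of ethyl and a number 43.3 percentage points higher from compound 1 to compound 4 (beyond the scatter) with ethoxy in place of fluoro, and none of these four compounds goes against this. No measurement given here accounts for it.

From the compounds shown here alone, whether a longer chain on that oxygen, such as butoxy, or an amine in the same place would hold the number stays open.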